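Bromine Moved Around the Ring: Tolerance in Cells

The source may report more compounds than this note shows. Statements on the series, on what has been measured and on what is new or still open speak of the compounds shown alone.

Measured compounds:
compound 1, `COc1ccc(-c2cnc(NC(=O)c3ccn[nH]3)n2C)cc1` — > 100000 nM
compound 2, `COc1ccc(-c2cnc(NC(=O)c3ccccc3Br)n2C)cc1` — > 100000 nM

In a toxicity assay on THP-1 cells (Homo sapiens) for inhibition (a higher number here means that more compound is tolerated, a lower number that less compound is tolerated), compound 2 gives > 100000 nM, which is a limit of the assay and not a number. Compound 1 likewise gives > 100000 nM in this assay, again a limit. Both values shown sit at the limit of > 100000 nM in this assay, at which 2 of the 2 values shown sit. The one measured step, a step that the two limits leave unreadable from compound 1 to compound 2, is therefore unreadable in size, and nothing in the shown numbers separates compound 2 from compound 1.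

Compound 3, `COc1ccc(-c2cnc(NC(=O)c3ccc(Br)cc3)n2C)cc1`, is yet to be measured in this assay. It differs from compound 2 by 4-bromophenyl in place of 2-bromophenyl on a carbonyl carbon. Among the compounds with values here, no measured step bears on this change, since the step from compound 1 to compound 2 cannot be read. The step this estimate means, a step that the limit leaves unreadable from compound 2 to compound 3, is expected to lie within the scatter. Compound 3 is accordingly expected at 150000 nM, with a range from 60000 nM to 400000 nM, most likely reported again as a limit.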

Compound 3, half-maximal cytotoxic concentration: > 100000 nM
Compound 3 gave a limit, no number; the forecaster's own chance of this, stated with the estimate: 75%; the middle value is on the limit's open side.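

In this assay compound 3 gives > 100000 nM, again a limit and not a number. Its steps from compound 1 and from compound 2 therefore cannot be read: the limit of > 100000 nM in this assay, at which 3 of the 3 values shown sit.

The compounds shown leave open what concentration of any of them the cells fail to tolerate, and whether 4-bromophenyl and 2-bromophenyl differ there.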